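The source may report more compounds than this note shows. Statements on the series, on what has been measured and on what is new or still open speak of the compounds shown alone.

Of the compounds shown here, three built on one shared core have been tested in an in vitro assay on cells for inhibition of Amine oxidase [flavin-containing] B (Homo sapiens), read by Amplex Red, with a stated time of 15 min; a higher number here means a weaker inhibitor, a lower number a stronger inhibitor. Compound 1 `Cc1ccc(/C=C/C(O)=C/C(=O)c2ccccc2O)cc1` gives 3770 nM. Compound 2 `O=C(/C=C(O)/C=C/c1ccccc1)c1ccccc1O` gives 1160 nM, and compound 3 `O=C(/C=C(O)/C=C/c1ccc(O)cc1)c1ccccc1O` gives 26.5 nM, the lowest of the three numbers and clearly apart from both others. Hydrogen in place of methyl on an aromatic carbon gives a 3.3-fold lower number from compound 1 to compound 2 (0.51 log units; beyond the scatter), a modest step, while hydroxy in place of methyl on that carbon gives a 140-fold lower number from compound 1 to compound 3 (2.15 log units; beyond the scatter), a large one.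

Compound 4 `O=C(/C=C(O)/C=C/c1ccc(O)c(O)c1)c1ccccc1O` has not been measured. It differs from compound 3 by hydroxy in place of hydrogen on an aromatic carbon. The step that bears on this most closely is the one that first put a hydroxy on that ring, which was a 44-fold lower number from compound 2 to compound 3 (1.64 log units; beyond the scatter); the change from compound 1 to compound 3 points the same way. A second hydroxy on a ring that already carries one is not bound to repeat a gain of that size, so for compound 4 a smaller downward step, or none beyond the scatter, is expected. The estimate for compound 4 in this assay is 15 nM, with a range from 4 nM to 60 nM, which corresponds to an expected 1.8-fold lower number from compound 3 to compound 4 (0.25 log units; within the scatter).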

Compound 4, half-maximal inhibitory concentration: 654 nM
For compound 4 the middle estimate is 44-fold (1.64 log units) below the measured one; the measured number lies above the stated range.
By their numbers in this assay, from the lowest: compound 3; then compounds 4 and 2 (each within the scatter of the next); then compound 1.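

In this assay, hydroxy in place of hydrogen on an aromatic carbon ortho to a hydroxy group gives a 25-fold higher number from compound 3 to compound 4 (1.39 log units; beyond the scatter), whereas the same swap at a different carbon of that ring gave a 44-fold lower number from compound 2 to compound 3 (1.64 log units; beyond the scatter). The same change can therefore push the number in opposite directions on one ring, so the outcome depends on which carbon receives the hydroxy, and compound 4 shows that adding a further hydroxy to compound 3 does not keep the gain. Nothing available here explains why the number rises at this position.

The compounds shown leave open whether the loss belongs to a hydroxy at this carbon alone or appears only when it is ortho to the existing hydroxy, a question that a compound carrying a single hydroxy at this carbon could settle. They also leave open how other groups would behave at this carbon, such as a methoxy group or a fluorine atom, and whether either would keep the low number of compound 3 at 26.5 nM.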